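Hydroxymethyl to hydrogen: expected shift for compound 4

The source may hold more compounds than are shown below. What is called first, only, known or untested is meant among the compounds shown, and "the series" means these compounds.

Values in a physicochemical assay for lipophilicity, using the shake flask method, in phosphate buffer, measured as octanol-water partition, with a stated time of 30 min, at pH 7.4; a higher number here means a more lipophilic compound, a lower number a more polar compound:
- compound 1 `O=C1c2ccccc2CN1c1cnc(NCc2c(F)ccc3c2CCO3)n2cnnc12`: 2.7
- compound 2 `C[C@@H]1CC(=O)N(c2cnc(NCc3c(F)ccc4c3CCO4)n3cnnc23)C1`: 1.8
- compound 3 `Cc1nc(CO)ccc1-c1cnc(NCc2c(F)ccc3c2CCO3)c2cn[nH]c(=O)c12`: 2.4

Compound 3 lies within the scatter of compound 1 and beyond the scatter above compound 2. Compound 4 `Cc1ncccc1-c1cnc(NCc2c(F)ccc3c2CCO3)c2cn[nH]c(=O)c12` differs from compound 3 as follows: hydrogen in place of hydroxymethyl on an aromatic carbon, that is, 6-(hydroxymethyl)-2-methylpyridin-3-yl to 2-methylpyridin-3-yl. Among the measured compounds shown here, only one measured step is available, a number 0.90 log units lower from compound 1 to compound 2 (beyond the scatter). It exchanges a different group on the core of compound 1, so it serves as a guide to size and not to direction. For the measured compounds named here, no measured pair isolates the loss of hydroxymethyl. Going by the values given here, a modest rise is expected, somewhat smaller than that step, and this direction remains a judgement that no measured pair tests. The estimated change is a number 0.60 log units higher from compound 3 to compound 4 (beyond the scatter). For compound 4 the estimated value is 3, with an expected range of 2.6 to 3.4.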

Compound 4, distribution coefficient: 3
Beside the measured number, compound 4's estimate shows no gap at the digits printed; the range from low to high includes it.
By their numbers in this assay, from the lowest: compound 2; then compounds 3, 1 and 4 (each within the scatter of the next, the first and the last beyond it).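

In this assay, among the compounds shown here, the change from 6-(hydroxymethyl)-2-methylpyridin-3-yl to 2-methylpyridin-3-yl gives a number 0.60 log units higher from compound 3 to compound 4 (beyond the scatter) and is the only measured pair that isolates hydroxymethyl, on the aromatic carbon next to the ring nitrogen. The earlier step, a number 0.90 log units lower from compound 1 to compound 2 (beyond the scatter), exchanged a different group on another core and gave no reading at this position, whereas the direction and size for this exchange are now measured, for this single pair. No available measurement bears on the reason for this shift.

From the compounds shown here alone, how an aminomethyl group, a carboxylic acid or a longer chain such as hydroxyethyl would read on the same aromatic carbon remains open. Also open, going by these compounds, is whether hydroxymethyl in place of hydrogen elsewhere on this ring would give a step of similar size.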